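From cyclopentyl to 2-methoxyphenyl on a carbonyl carbon

The source may report more compounds than this note shows. Statements on the series, on what has been measured and on what is new or still open speak of the compounds shown alone.

In a toxicity assay on THP-1 cells (Homo sapiens) for inhibition (a higher number here means that more compound is tolerated, a lower number that less compound is tolerated), compound 3 (`COc1ccc(-c2cnc(NC(=O)C3CCCC3)n2C)cc1`) gives > 100000 nM as a limit of the assay, not a number. Compound 1 (`COc1ccc(-c2cnc(NC(=O)c3ccc(C)cc3)n2C)cc1`) gives > 100000 nM as a limit as well. Compound 2 (`COc1ccc(-c2cnc(NC(C)=O)n2C)cc1`) gives > 100000 nM as a limit too. The series thus stands at the limit of > 100000 nM in this assay, at which 3 of the 3 values shown sit, and compound 3 has no readable rank within it.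

Compound 4 (`COc1ccc(-c2cnc(NC(=O)c3ccccc3OC)n2C)cc1`) carries 2-methoxyphenyl in place of cyclopentyl on a carbonyl carbon. For the measured compounds named here, three measured steps concern that same carbonyl carbon: a step that the two limits leave unreadable from compound 1 to compound 2 for methyl in place of 4-methylphenyl, a step that the two limits leave unreadable from compound 1 to compound 3 for cyclopentyl in place of 4-methylphenyl, and a step that the two limits leave unreadable from compound 2 to compound 3 for cyclopentyl in place of methyl. The second, read in reverse, comes closest to the present change, but none of the three yields a size or a direction.

Going by the values given here, with the limit of > 100000 nM in this assay, at which 3 of the 3 values shown sit, as the only guide, no step beyond the scatter is expected in this assay and no direction is forecast. The expected outcome is a number no higher from compound 3 to compound 4 (the limit leaves the size open) as the estimated step. For compound 4 the estimate is 100000 nM as an expected value, within an estimated range of 50000 nM to 200000 nM and most likely reported only as a limit.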

Compound 4, half-maximal cytotoxic concentration: > 100000 nM
Compound 4 ended at the assay's limit; the forecaster's own chance of this, stated with the estimate: 85%; the middle value sits exactly at the limit.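

In this assay compound 4 gives > 100000 nM, a limit of the assay and not a number. The steps from compounds 1, 2 and 3 to compound 4 therefore cannot be read: the limit of > 100000 nM in this assay, at which 4 of the 4 values shown sit.

The compounds shown leave open at what concentration any of them becomes toxic to these cells, and whether the groups on the carbonyl carbon differ in this respect.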